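A few compounds are considered here, and "the series" means these few. Any claim that something is new, unique, unknown or untested is made for them only; others in the source may bear on it.

Measured compounds:
Compound 1 `CCCC(C)Nc1oc2c(C)ncc(CO)c2c1Nc1ccccn1` gives 9010 nM in a functional assay on HEK293 cells for agonist activity at Toll-like receptor 8 (Homo sapiens), read by reporter gene assay; on this read-out higher numbers stand for an effect only at larger amounts of compound and lower numbers for an effect already at smaller amounts.
Compound 2 `Cc1ncc(CO)c2c(Nc3ccccn3)c(NC[Si](C)(C)C)oc12` gives 4990 nM in this assay.
Compound 3 `CCCCCNc1oc2c(C)ncc(CO)c2c1Nc1ccccc1` gives 2250 nM in this assay.

Compound 2 stands second highest of these three numbers. Its nearest neighbour is compound 1, which sits within the scatter of it; compound 3 lies furthest away, with a lower number that falls beyond the scatter, though compound 3 differs from compound 2 in more than one place, so the two values can only be compared as they stand.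

The step from compound 2 to compound 4 `Cc1ncc(CO)c2c(Nc3ccccn3)c(NC(C)(C)C)oc12` is this: a group of 4 heavy atoms (4 carbon; no ring) in place of a group of 5 heavy atoms (4 carbon, 1 silicon; no ring), on a nitrogen on an aromatic ring. For the measured compounds named here, the one measured step that bears on it is the exchange of a five-atom chain for another five-atom group on the same nitrogen, a 1.8-fold lower number from compound 1 to compound 2 (0.26 log units; within the scatter). That step moved the number only within the scatter, so a further exchange on this nitrogen is expected to have at most a modest effect in this assay, with no clear direction.

Compound 4 is therefore estimated at 6000 nM, with a range from 2500 nM to 15000 nM, which means an expected step of a 1.2-fold higher number from compound 2 to compound 4 (0.08 log units; within the scatter).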

Compound 4, half-maximal effective concentration: "not active" (no number reported)
Compound 4 has no reported number here; no gap can be computed for the estimate.
By their numbers in this assay, from the lowest: compound 3; then compounds 2 and 1 (each within the scatter of the next).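

For the compounds shown here, compound 4 is reported as "not active" in this assay, without a number, and no step from compound 2 to compound 4 can be read. Nothing available here bears on this result. The compounds shown leave open how far the tert-butyl group on this nitrogen separates compound 4 from compound 2.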